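The compounds below may be only part of what the source reports. "The series", "measured", "known", "first", "only" and "open" are said of these compounds alone.

Compounds measured so far:
Compound 1 `COc1cc(/C=C2\CCC/C(=C\c3ccc(F)c(F)c3)C2=O)cc(OC)c1OC`: 3500 nM
Compound 2 `COc1cc(/C=C2\CCC/C(=C\c3ccc(O)c(O)c3)C2=O)cc(OC)c1OC`: 3600 nM

In a functional assay on T84 cells (Homo sapiens) for antiproliferative activity, read by MTT assay, with a stated time of 72 h (a higher number here means a weaker inhibitor, a lower number a stronger inhibitor), compound 2 gives 3600 nM. Going by the values given here, the only measured step, a 1.0-fold higher number from compound 1 to compound 2 (0.01 log units; within the scatter), is within the scatter, so compound 1 and compound 2 cannot be told apart on these numbers. Compound 3 `COc1cc(/C=C2\CCC/C(=C\c3cccc(O)c3)C2=O)cc(OC)c1OC` differs from compound 2 by hydrogen in place of hydroxy on an aromatic carbon. Among the compounds with values here, no measured step tests such a change; the one step known left the number unmoved. A step of no more than the scatter is therefore expected, in no set direction. Compound 3 is estimated at 3600 nM, between 1500 nM and 9000 nM. This estimate means no change at the digits printed from compound 2 to compound 3 (within the scatter).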

Compound 3, half-maximal inhibitory concentration: 6500 nM
The estimate for compound 3 lay 1.8-fold (0.26 log units) below the measured number; measured number inside the range.
By their numbers in this assay, from the lowest: compounds 1, 2 and 3 (each within the scatter of the next).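

In this assay, going by these compounds alone, this is the first test of the hydroxy group itself: with hydrogen in its place, on the carbon ortho to a hydroxy group and para to a large group, the result is a 1.8-fold higher number from compound 2 to compound 3 (0.26 log units; within the scatter), so the 3,4-dihydroxyphenyl pattern is not needed to stay within the scatter. The 3-hydroxyphenyl ring, set against 3,4-difluorophenyl, gives a 1.9-fold higher number from compound 1 to compound 3 (0.27 log units; within the scatter), also within the scatter. No other data bear on this result. Still open, as far as these compounds go, is whether an amine or a carboxylic acid at this position would give a step beyond the scatter.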